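Carbamate on the phenolic oxygen of compound 1

The source may hold more compounds than are shown below. What is called first, only, known or untested is meant among the compounds shown, and "the series" means these compounds.

Compound 1 `CC(C)=CCC1Cc2c(O)cc(=O)n(CCCO)c2CC1(C)C` is the parent of this small series. In a functional assay on PANC-1 cells (Homo sapiens) for inhibition, read by MTT assay, with a stated time of 24 h, tested at 10 uM (on this read-out lower numbers stand for less inhibition and higher numbers for more inhibition at the one concentration tested (going by the name of the read-out)), compound 1 gives 0%, the lowest of the two numbers measured. Compound 2 `CC(C)=CCC/C(C)=C/COc1cc(=O)n(CCCO)c2c1CC(CC=C(C)C)C(C)(C)C2` differs from it only by 3,7-dimethylocta-2,6-dien-1-yl in place of hydrogen on an oxygen on an aromatic ring, and in this assay compound 2 gives 18.4%; the step is a number 18.4 percentage points higher from compound 1 to compound 2 (beyond the scatter).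

Compound 3 `CC(C)=CCC1Cc2c(OC(=O)Nc3ccc(F)c(F)c3)cc(=O)n(CCCO)c2CC1(C)C` is the next variation on the same oxygen: (3,4-difluorophenyl)carbamoyl in place of hydrogen on an oxygen on an aromatic ring. Within the data shown here, the only step that bears on it is the one from compound 1 to compound 2, where substituting hydrogen on that oxygen raised inhibition modestly. Among the measured compounds shown here, a (3,4-difluorophenyl)carbamoyl group is a different kind of substituent from the dienyl chain, so the one measured step is only loose guidance. A modest rise beyond the scatter is nevertheless the expectation, a number 15 percentage points higher from compound 1 to compound 3 (beyond the scatter). Compound 3 is therefore estimated at 15%, with a plausible range from 0% to 35%.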

Compound 3, a percentage reported as inhibition, at one concentration (the size of the read-out at that concentration, not a potency): 0%
The estimate for compound 3 lay 15 percentage points above the measured number; measured number inside the range.
By their numbers in this assay, from the lowest: compounds 1 and 3 (each within the scatter of the next); then compound 2.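

In this assay, (3,4-difluorophenyl)carbamoyl on the oxygen on an aromatic ring leaves the read-out in place, with no change at the digits printed from compound 1 to compound 3 (within the scatter). Replacing the hydrogen on this oxygen is therefore not enough in itself: exchanging 3,7-dimethylocta-2,6-dien-1-yl for this carbamoyl gives a number 18.4 percentage points lower from compound 2 to compound 3 (beyond the scatter), so at this position the read-out depends on which group enters. No measurement at hand accounts for the difference between these two groups.

Still open, as far as these compounds go, is whether the inhibition seen with the dienyl group follows from the length of that chain, which a shorter 3-methylbut-2-en-1-yl chain on the same oxygen would test. From the compounds shown here alone, it is also open whether the carbamate linkage as such gives this flat result, which a simple ethylcarbamoyl or a phenylcarbamoyl without the two fluorines could help to settle.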